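A Ring Swap on Compound 2

A few compounds are considered here, and "the series" means these few. Any claim that something is new, unique, unknown or untested is made for them only; others in the source may bear on it.

In a functional assay on S1 cells (Homo sapiens) for cytotoxicity, read by MTT assay, with a stated time of 72 h (on this read-out higher numbers stand for weaker inhibition and lower numbers for stronger inhibition), compound 1 `COc1ccc(/C=C/c2cc(C)n[nH]2)cc1` gives 8400 nM as a measured number. Compound 2 `COc1ccc(/C=C/c2cc(C)no2)cc1OC` reads > 100000 nM and that entry is a limit, not a number. Compound 3 `COc1ccc(/C=C/c2cc(C)n[nH]2)cc1OC` differs from compound 2 in one place: 3-methyl-1H-pyrazol-5-yl in place of 3-methyl-1,2-oxazol-5-yl on a double-bonded chain carbon bound to a double-bonded chain carbon with 3-methyl-1H-pyrazol-5-yl in place of 3-methyl-1,2-oxazol-5-yl on a double-bonded chain carbon bound to a double-bonded chain carbon. In this assay compound 1, which carries the same 3-methyl-1H-pyrazol-5-yl, gives 8400 nM and so a large move toward stronger inhibition, well beyond the scatter, is expected. The estimated step of an at least 8.3-fold lower number from compound 2 to compound 3 (0.92 log units; beyond the scatter) points in that direction, although compound 1 and compound 2 differ in more than this one place. Compound 3 is estimated at 12000 nM with an expected range from 3000 nM to 50000 nM overall.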

Compound 3, half-maximal inhibitory concentration: 22400 nM
Estimate against measurement, compound 3: 1.9-fold (0.27 log units) below; measured number inside the range.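

In this assay, 3-methyl-1H-pyrazol-5-yl in place of 3-methyl-1,2-oxazol-5-yl gives an at least 4.4-fold lower number from compound 2 to compound 3 (0.64 log units; beyond the scatter), which reads the ring change on its own in a pair that differs in this one place only. The entry for compound 2 is a limit and not a number, so this step gives only a minimum size: the limit of > 100000 nM in this assay, at which 1 of the 3 values shown sits. The second new step shows that, with the 3-methyl-1H-pyrazol-5-yl kept, methoxy in place of hydrogen on an aromatic carbon gives a 2.7-fold higher number from compound 1 to compound 3 (0.43 log units; beyond the scatter), a modest loss that leaves compound 1 the stronger of this pair.

From the compounds shown here alone, how far the ring change reaches beyond that minimum remains open, as does whether the methoxy step would keep its size with 3-methyl-1,2-oxazol-5-yl. Going by these compounds, what an amine or a carboxylic acid in place of the methyl on the ring would give also remains open.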